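Swapping a Methylphenyl for a Dimethylfuran on the Amide

This account rests on a few compounds, and the source may have more. Where it says the series, first, only, none or still open, it means among the compounds named here.

Measured so far:
compound 1 `O=C(Nc1ccc2nc(NC(=O)C3CCCCC3)sc2c1)c1ccccc1Cl` gives 0.025 ug/mL in a functional assay on WI-38 VA13 cells (Homo sapiens) for cytotoxicity; a higher number here means that more compound is needed for the effect, a lower number that less compound is needed.
compound 2 `Cc1ccc(C(=O)Nc2ccc3nc(NC(=O)C4CCCCC4)sc3c2)cc1` gives 5.1 ug/mL in this assay.
compound 3 `O=C(Nc1ccc2nc(NC(=O)C3CCCCC3)sc2c1)c1ccc(Br)cc1` gives > 4 ug/mL in this assay, which is a limit of the assay and not a number.

Compound 2 stands highest of the two readable numbers. For the measured compounds named here, the one step leading to it, a 200-fold higher number from compound 1 to compound 2 (2.31 log units; beyond the scatter), is large and was made on the carbonyl carbon. The step that the limit leaves unreadable from compound 2 to compound 3 is unreadable because of the limit of > 4 ug/mL in this assay, at which 1 of the 3 values shown sits.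

Compound 4 `Cc1coc(C)c1C(=O)Nc1ccc2nc(NC(=O)C3CCCCC3)sc2c1` differs from compound 2 by 2,4-dimethylfuran-3-yl in place of 4-methylphenyl on a carbonyl carbon. Going by the values given here, no measured step tests this exchange of aromatic rings. With nothing pointing either way, the step is expected to stay within the scatter, a 1.2-fold higher number from compound 2 to compound 4 (0.07 log units; within the scatter). Compound 4 is therefore estimated at 6 ug/mL, in the range 1.5 ug/mL to 25 ug/mL.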

Compound 4, half-maximal effective concentration: 2.7 ug/mL
For compound 4 the middle estimate is 2.2-fold (0.35 log units) above the measured one; the measured number falls inside the stated range.
By their numbers in this assay, from the lowest: compound 1; then compounds 4 and 2 (each within the scatter of the next).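

The 2,4-dimethylfuran-3-yl ring, which brings a hydrogen-bond acceptor, can stand on this carbonyl carbon in place of 4-methylphenyl with the number staying within the scatter in this assay, with a 1.9-fold lower number from compound 2 to compound 4 (0.28 log units; within the scatter). The comparison with 4-bromophenyl gives only a floor, an at least 1.4-fold lower number from compound 3 to compound 4 (0.17 log units; that floor lies within the scatter), and it rests on a limit, not a number: the limit of > 4 ug/mL in this assay, at which 1 of the 4 values shown sits. The furan does not come close to 2-chlorophenyl, with a 110-fold higher number from compound 1 to compound 4 (2.03 log units; beyond the scatter), so compound 1 remains alone at the low end.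

On these data alone, whether the low number of compound 1 comes from chlorine itself or from its place on the ring stays open. As far as these compounds go, how a pyridine ring on this carbonyl carbon would read also stays open.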